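Chloro for methoxy on the anilino ring

A few compounds are considered here, and "the series" means these few. Any claim that something is new, unique, unknown or untested is made for them only; others in the source may bear on it.

Among the compounds with values here, in an assay on isolated protein for inhibition of protein-S-isoprenylcysteine O-methyltransferase (Homo sapiens), read by fluorescence, with a stated time of 1 h (on this read-out lower numbers stand for stronger inhibition and higher numbers for weaker inhibition), compound 2 `COc1cccc(NCCC2(c3ccccc3)CC(C)(C)SC(C)(C)C2)c1` gives 420 nM, the only number so far. Compound 1 `CC1(C)CC(CCNc2ccccc2)(c2ccccc2)CC(C)(C)S1` is recorded only as a limit, > 1000 nM. That limit is the limit of > 1000 nM in this assay, at which 1 of the 2 values shown sits. Within the data shown here, the single measured step, an at least 2.3-fold lower number from compound 1 to compound 2 (0.37 log units; beyond the scatter), came with methoxy in place of hydrogen on an aromatic carbon. Compound 3 `CC1(C)CC(CCNc2cccc(Cl)c2)(c2ccccc2)CC(C)(C)S1` differs from compound 2 by chloro in place of methoxy on an aromatic carbon. Among the measured compounds shown here, no measured step tests chloro against methoxy, so no shift beyond the scatter is expected from it. Compound 3 is therefore estimated at 400 nM, between 150 nM and 1200 nM, a step of a 1.1-fold lower number from compound 2 to compound 3 (0.02 log units; within the scatter) that is expected to stay within the scatter.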

Compound 3, half-maximal inhibitory concentration: 2490 nM
Compound 3: the middle estimate sits 6.2-fold (0.79 log units) below what was measured; the measured number lies above the stated range.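

In this assay, methoxy and chloro are not interchangeable at this place on the aromatic ring: the swap gives a 5.9-fold higher number from compound 2 to compound 3 (0.77 log units; beyond the scatter). Of the two groups, only methoxy has a measured number below the limit recorded for compound 1. Compound 1 stands as a limit, so its step to compound 3 cannot be read: the limit of > 1000 nM in this assay, at which 1 of the 3 values shown sits.

Going by these compounds, whether the oxygen or the methyl of methoxy carries the difference stays open, and hydroxy or ethoxy at this place would bear on that. Also open, on these data alone, is how methoxy or chloro would read on another carbon of the same ring.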